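One Added Methyl on a Compound at the Limit

The source may report more compounds than this note shows. Statements on the series, on what has been measured and on what is new or still open speak of the compounds shown alone.

Compound 1 `Cc1cc(O)c(C(=O)/C=C/c2ccc(Cl)cc2)c(=O)o1` gives 87400 nM
Compound 2 `COc1ccc(/C=C/C(=O)c2c(O)cc(C)oc2=O)cc1` gives > 100000 nM (a limit, not a number)

In a functional assay on HCT-116 cells (Homo sapiens) for cytotoxicity, read by MTT assay (a lower number here means a stronger inhibitor, a higher number a weaker inhibitor), compound 2 gives > 100000 nM as its result, and that is a limit of the assay and not a number. Its exact position is therefore unknown.

Compound 3 `CCOc1ccc(/C=C/C(=O)c2c(O)cc(C)oc2=O)cc1` carries methyl in place of hydrogen on a saturated chain carbon bound to an oxygen on an aromatic ring and so the methoxy of compound 2 becomes an ethoxy.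

For the measured compounds named here, only one measured step bears on this change. It is an at least 1.1-fold higher number from compound 1 to compound 2 (0.05 log units; that floor lies within the scatter) and it puts methoxy in place of chloro on an aromatic carbon. That step does not touch the methoxy chain itself, so it is only a loose guide, and it shows no change beyond the scatter.

On that basis, no step beyond the scatter is expected in this assay and no direction can be favoured. The estimated change is a number no higher from compound 2 to compound 3 (the limit leaves the size open) and it stays small.

For compound 3 the estimate is 100000 nM with an expected range from 50000 nM to 200000 nM around it.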

Compound 3, half-maximal inhibitory concentration: > 100000 nM
Compound 3 gave a limit, no number; the forecaster's own chance of this, stated with the estimate: 65%; the middle value lies on the limit itself.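

In this assay compound 3 gives > 100000 nM, which is a limit of the assay and not a number, so the ethoxy compound yields no measured value, just as the methoxy compound did. The effect of the added methyl cannot be read, because both compounds stop at the same limit: the limit of > 100000 nM in this assay, at which 2 of the 3 values shown sit. For the compounds shown here, the only step that can be read, where an ethoxy group stands instead of the chloro group, is an at least 1.1-fold higher number from compound 1 to compound 3 (0.05 log units; that floor lies within the scatter).

On these data alone, the true values of compound 2 and compound 3 remain unknown, and so do the size and direction of the change from methoxy to ethoxy. Also open, as far as these compounds go, is whether a longer chain such as butoxy, or an amine in place of the ethoxy, would bring the result back within the range of the assay and give an actual number.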